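The source may report more compounds than this note shows. Statements on the series, on what has been measured and on what is new or still open speak of the compounds shown alone.

Measured so far:
Compound 1 `CC1CCN(C2CCN(S(=O)(=O)c3nccn3C)CC2)CC1` gives > 5000 nM in a functional assay on DLD-1 cells (Homo sapiens) for antiproliferative activity, read by CellTiter-Glo, with a stated time of 72 h; on this read-out lower numbers stand for stronger inhibition and higher numbers for weaker inhibition.
Compound 2 `Cc1cc(C)c(S(=O)(=O)N2CCC(N3CCCCCC3)CC2)c(C)c1` gives 5.3 nM in this assay.
Compound 3 `COc1ccc(NC(=O)N2CCC(N3CCC(C)CC3)CC2)cc1` gives 1360 nM in this assay.

The figure for compound 1 is a limit of the assay and not a number: the limit of > 5000 nM in this assay, at which 1 of the 3 values shown sits. Compound 1 thus stands at the weak end of what has been measured, while compound 2 and compound 3 each give a real number inside the measurable range.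

Compound 4 `CCc1ccc(S(=O)(=O)N2CCC(N3CCC(C)CC3)CC2)cc1` has not yet been measured. It differs from compound 1 in a single place: 4-ethylphenyl in place of 1-methyl-1H-imidazol-2-yl on a sulfonyl sulfur. Going by the values given here, no two measured compounds differ from each other in just one place, so no measured step speaks directly to this change. Compound 2, which also carries a six-membered aromatic ring of carbon only on its sulfonyl sulfur, gives 5.3 nM, and in its light compound 4 is expected to gain strongly, by an at least 120-fold lower number from compound 1 to compound 4 (2.09 log units; beyond the scatter), a step far beyond the scatter. Compound 4 is therefore estimated at 40 nM, with a range from 8 nM to 300 nM.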

Compound 4, half-maximal inhibitory concentration: > 5000 nM
Compound 4 was reported as a limit; the forecaster's own chance of this, stated with the estimate: 5%; at least 120-fold (2.09 log units) between middle value and limit.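

Compound 1 and compound 4 each give a limit of the assay and not a number, so no step between them can be read: the limit of > 5000 nM in this assay, at which 2 of the 4 values shown sit.

The compounds shown leave open whether 4-ethylphenyl in place of 1-methyl-1H-imidazol-2-yl on a sulfonyl sulfur changes the activity at all.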